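From 4-methoxyphenyl to thiophen-2-yl on a carbonyl carbon

The compounds below may be only part of what the source reports. "The series", "measured", "known", "first", "only" and "open" are said of these compounds alone.

In an ADME assay on cells (Hepatocyte, Homo sapiens) for metabolic stability, with a stated time of 30 min (a higher number here means that more of the compound is left, a lower number that less of the compound is left), compound 1 `O=C(OC1CCC(CN2CCN(c3cc(=O)c4cc(C(F)(F)F)cc([N+](=O)[O-])c4s3)CC2)CC1)c1ccccc1` gives 56.4% while compound 2 `CC(=O)NC1CCC(CN2CCN(c3cc(=O)c4cc(C(F)(F)F)cc([N+](=O)[O-])c4s3)CC2)CC1` gives 86.8% and compound 3 `COc1ccc(C(=O)OC2CCC(CN3CCN(c4cc(=O)c5cc(C(F)(F)F)cc([N+](=O)[O-])c5s4)CC3)CC2)cc1` gives 12.2% as the lowest of the three. Compound 4 `O=C(OC1CCC(CN2CCN(c3cc(=O)c4cc(C(F)(F)F)cc([N+](=O)[O-])c4s3)CC2)CC1)c1cccs1` differs from compound 3 by carrying thiophen-2-yl in place of 4-methoxyphenyl on a carbonyl carbon. The closest measured guide is a number 44.2 percentage points lower from compound 1 to compound 3 (beyond the scatter) for methoxy in place of hydrogen on an aromatic carbon, while a number 74.6 percentage points lower from compound 2 to compound 3 (beyond the scatter) swaps a whole group and guides less. Among the measured compounds shown here, compound 4 has no methoxy, like compound 1 with its 56.4% result, so a large rise is expected, although no thiophen-2-yl compound has been measured. In this assay the expected step is a number 27.8 percentage points higher from compound 3 to compound 4 (beyond the scatter) by this estimate. Compound 4 is estimated at 40% with 15% to 65% as its range.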

Compound 4, percent of the compound remaining: 2.2%
Estimate against measurement, compound 4: 37.8 percentage points above; the whole stated range lies above it.
By their numbers in this assay, from the lowest: compounds 4 and 3 (each within the scatter of the next); then compound 1; then compound 2.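

In this assay, thiophen-2-yl on this carbonyl carbon reads the same as 4-methoxyphenyl (a number 10 percentage points lower from compound 3 to compound 4 (within the scatter)), so the absence of the methoxy alone does not restore the level of compound 1. The ring on the carbonyl therefore matters, since swapping phenyl for thiophen-2-yl gives a large step (a number 54.2 percentage points lower from compound 1 to compound 4 (beyond the scatter)), and acetamido in place of the whole ester group stands further off still (a number 84.6 percentage points lower from compound 2 to compound 4 (beyond the scatter)). Nothing measured here gives a reason for these differences.

Still open, going by these compounds, is whether furan-2-yl or pyridin-3-yl on this carbonyl carbon would read like compound 1 or like compound 4. Also open, on these data alone, is how a benzamide, with nitrogen in place of the ester oxygen, would compare with compound 1.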